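From 1,3-thiazol-5-yl to 1-methyl-1H-pyrazol-5-yl on the carbonyl carbon

The source may hold more compounds than are shown below. What is called first, only, known or untested is meant among the compounds shown, and "the series" means these compounds.

In a functional assay on A549 cells (Homo sapiens) for inhibition, read by colorimetric assay and sulforhodamine B assay, with a stated time of 48 h (a higher number here means a weaker inhibitor of growth, a lower number a stronger inhibitor of growth), compound 1 `CCCCCCCCCCCC[C@@H](O)[C@H]1CC[C@H]([C@H](O)CCCCCCCCCCNC(=O)c2ccoc2)O1` gives 100000 nM and compound 2 `CCCCCCCCCCCC[C@@H](O)[C@H]1CC[C@H]([C@H](O)CCCCCCCCCCNC(=O)c2cncs2)O1` gives 34700 nM, the lower of the two numbers. Compound 3 `CCCCCCCCCCCC[C@@H](O)[C@H]1CC[C@H]([C@H](O)CCCCCCCCCCNC(=O)c2ccnn2C)O1` changes compound 2 on the carbonyl carbon: 1-methyl-1H-pyrazol-5-yl in place of 1,3-thiazol-5-yl on a carbonyl carbon. Within the data shown here, only one measured step bears on this change, the modest 2.9-fold lower number from compound 1 to compound 2 (0.46 log units; beyond the scatter), which also exchanges one ring at that carbon. This single step gives no firm direction, so no step beyond the scatter is expected. The estimated step is a 1.2-fold higher number from compound 2 to compound 3 (0.06 log units; within the scatter). For compound 3, the expected value is 40000 nM, with an estimated range of 15000 nM to 100000 nM.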

Compound 3, concentration for 50% growth inhibition: 12900 nM
The estimate for compound 3 lay 3.1-fold (0.49 log units) above the measured number; measured number outside the range, below it.
By their numbers in this assay, from the lowest: compound 3; then compound 2; then compound 1.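

Both a 2.7-fold lower number from compound 2 to compound 3 (0.43 log units; beyond the scatter) and a 7.8-fold lower number from compound 1 to compound 3 (0.89 log units; beyond the scatter) in this assay show that the ring on this carbonyl carbon can shift growth inhibition further than the first pair suggested. Among these three compounds, the numbers fall from furan-3-yl through 1,3-thiazol-5-yl to 1-methyl-1H-pyrazol-5-yl, with each step beyond the scatter. No evidence is available to explain this order. Going by these compounds, whether a phenyl group or a dimethylamino group in place of the ring on this carbonyl carbon would continue the trend stays open.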